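Chain extension and MCF7 antiproliferative potency: working notes

A few compounds are considered here, and "the series" means these few. Any claim that something is new, unique, unknown or untested is made for them only; others in the source may bear on it.

compound 1, `CCCCCCCCCCNC[C@@H]1OC[C@H](N)[C@@H]1O`: 34200 nM
compound 2, `CCCCCCCCCCCCNC[C@@H]1OC[C@H](N)[C@@H]1O`: 1800 nM
compound 3, `CCCCCCCCNC[C@@H]1OC[C@H](N)[C@H]1O`: > 128000 nM (a limit of the assay, not a number)

In a functional assay on MCF7 cells (Homo sapiens) for antiproliferative activity, read by MTT assay, with a stated time of 72 h (on this read-out lower numbers stand for stronger inhibition and higher numbers for weaker inhibition), compound 1 gives 34200 nM and compound 2 gives 1800 nM. The change ethyl in place of hydrogen on a saturated chain carbon, ten or more bonds along the chain from an amine nitrogen produces a 19-fold lower number from compound 1 to compound 2 (1.28 log units; beyond the scatter). For compound 3 this assay reports only a limit, (the limit of > 128000 nM in this assay, at which 1 of the 3 values shown sits). Compound 4, `CCCCCCCCCCNC[C@@H]1OC[C@H](N)[C@H]1O`, is not yet measured; it differs from compound 3 by ethyl in place of hydrogen on a saturated chain carbon, eight bonds along the chain from an amine nitrogen. This is the same kind of change as that from compound 1 to compound 2, though the place along the chain differs, as the two differences show. The difference between the core of compound 1 and that of compound 3 is not broken down here. The step is expected to run in the same direction as a 19-fold lower number from compound 1 to compound 2 (1.28 log units; beyond the scatter), so an at least 2.1-fold lower number from compound 3 to compound 4 (0.32 log units; beyond the scatter) is the expectation, with wide uncertainty since compound 3 gives only a limit. Compound 4 is estimated at 60000 nM, between 12000 nM and 200000 nM.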

Compound 4, half-maximal inhibitory concentration: 42700 nM
For compound 4 the middle estimate is 1.4-fold (0.15 log units) above the measured one, and the stated range covers the measured number.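

In this assay ethyl in place of hydrogen on the chain goes with a lower number on both cores, so the direction carries over, but the size of the step on the second core stays undetermined: the same change on two cores in this assay, a 19-fold lower number (1.28 log units; beyond the scatter) from compound 1 to compound 2 and an at least 2.9-fold lower number (0.47 log units; beyond the scatter) from compound 3 to compound 4; the limit leaves it open whether they differ

Compound 3 gives > 128000 nM, a limit of the assay and not a number, so an at least 2.9-fold lower number from compound 3 to compound 4 (0.47 log units; beyond the scatter) is a bound only.

The stereocentre at a saturated ring carbon gives a 1.2-fold higher number from compound 1 to compound 4 (0.10 log units; within the scatter), so at this chain the two cores are not told apart: the fact that compounds 1 and 4 differ only in the configuration as drawn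

The compounds shown leave open whether a longer chain on the core of compound 3 lowers the number further, as the step to compound 2 did on the other core. Also open, from the compounds shown here alone, is whether an amide in place of the chain amine keeps the activity.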